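Replacing the cyclopropylphenyl arm: an expectation for compound 4

The compounds below may be only part of what the source reports. "The series", "measured", "known", "first", "only" and "open" are said of these compounds alone.

Compound 1, `Cc1cccc(Nc2nc(N)nc(COc3ccc4c(C)cc(=O)oc4c3)n2)c1`: 1780 nM
Compound 2, `Cc1cc(=O)oc2cc(OCc3nc(N)nc(Nc4cccc(Cl)c4)n3)ccc12`: 1110 nM
Compound 3, `Cc1cc(=O)oc2cc(OCc3nc(N)nc(Nc4ccc(C5CC5)cc4)n3)ccc12`: 700 nM

These three compounds share one core and differ only in the aromatic group attached to a nitrogen on an aromatic ring. All were tested in an assay on COS-7 cells for agonist activity at Free fatty acid receptor 1 (Homo sapiens), read by scintillation counting and inositol phosphate accumulation, with a stated time of 90 min; a lower number here means that less compound is needed, a higher number that more compound is needed for the effect. Compound 3 sits at the low end of the three numbers: the step of a 2.5-fold lower number from compound 1 to compound 3 (0.41 log units; beyond the scatter) lies beyond the scatter, whereas compound 2 and compound 3 lie within the scatter of each other, as a 1.6-fold lower number from compound 2 to compound 3 (0.20 log units; within the scatter) shows.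

Compound 4, `Cc1cc(=O)oc2cc(OCc3nc(N)nc(Nc4ccc5c(c4)COC5)n3)ccc12`, has not yet been measured in this assay. It differs from compound 3 in one place: a group of 9 heavy atoms (8 carbon, 1 oxygen; one five-membered non-aromatic ring with 1 hetero atom, one six-membered aromatic ring of carbon only) in place of a group of 9 heavy atoms (9 carbon; one three-membered non-aromatic ring of carbon only, one six-membered aromatic ring of carbon only), on a nitrogen on an aromatic ring. For the measured compounds named here, no measured step involves the entering group, so the only guidance comes from the other exchanges of the aromatic group, a 1.6-fold lower number from compound 1 to compound 2 (0.21 log units; within the scatter), a 2.5-fold lower number from compound 1 to compound 3 (0.41 log units; beyond the scatter) and a 1.6-fold lower number from compound 2 to compound 3 (0.20 log units; within the scatter). All of these were small, and two of them fell within the scatter. On that basis a small step is expected in this assay, with no clear direction, and most likely nothing beyond the scatter.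

Compound 4 is therefore estimated at 800 nM, with a range from 300 nM to 2500 nM. This estimate means an expected step of a 1.1-fold higher number from compound 3 to compound 4 (0.06 log units; within the scatter).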

Compound 4, half-maximal effective concentration: 1330 nM
Estimate against measurement, compound 4: 1.7-fold (0.22 log units) below; low and high end bracket the measured number.
By their numbers in this assay, from the lowest: compounds 3, 2, 4 and 1 (each within the scatter of the next, the first and the last beyond it).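

In this assay, placing the group with a five-membered non-aromatic ring holding one oxygen on the nitrogen, in place of 4-cyclopropylphenyl, keeps the count at 9 heavy atoms, adds 1 hydrogen-bond acceptor and gives a 1.9-fold higher number from compound 3 to compound 4 (0.28 log units; within the scatter). Set against the two other arms, the same group gives a 1.2-fold higher number from compound 2 to compound 4 (0.08 log units; within the scatter) and a 1.3-fold lower number from compound 1 to compound 4 (0.13 log units; within the scatter), so compound 4 lies within the scatter of all three earlier compounds, even though compound 1 and compound 3 lie beyond the scatter of each other. This position therefore carries an arm with a hydrogen-bond acceptor and a second ring joined to the phenyl ring without any step beyond the scatter, though no available evidence explains the small differences seen here.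

The role of the ring oxygen stays open, since no compound shown pairs this arm with a matching five-membered ring of carbon only. Also open, on these data alone, is whether a more different group on the phenyl ring, such as an amine or a carboxylic acid, would produce a step beyond the scatter.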